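A Repeated Side-Chain Swap on Two Related Cores

This account rests on a few compounds, and the source may have more. Where it says the series, first, only, none or still open, it means among the compounds named here.

Compound 1 `Cn1nc(-c2nnc(SCc3c(F)cccc3F)o2)cc1-c1ccc(C(F)(F)F)cc1` and compound 2 `Cn1nc(-c2nnc(SCCOc3ccccc3F)o2)cc1-c1ccc(C(F)(F)F)cc1` share one core, while compound 3 `Cn1nc(-c2ccc(C(F)(F)F)cc2)cc1-c1nnc(SCc2c(F)cccc2F)o1` and compound 4 `Cn1nc(-c2ccc(C(F)(F)F)cc2)cc1-c1nnc(SCCOc2ccccc2F)o1` share another; the difference between the two cores is not broken down here. In a functional assay on Ehrlich cells (Mus musculus) for cytotoxicity, read by MTT assay, with a stated time of 24 h (a higher number here means a weaker inhibitor, a lower number a stronger inhibitor), compound 1 gives 28200 nM, compound 2 gives 25200 nM, and compound 3 gives 38500 nM. The change from compound 1 to compound 2, ((2-fluorophenoxy)methyl in place of 2,6-difluorophenyl on a saturated chain carbon bound to a sulfur), produced a step of a 1.1-fold lower number from compound 1 to compound 2 (0.05 log units; within the scatter). The same kind of change, ((2-fluorophenoxy)methyl in place of 2,6-difluorophenyl on a saturated chain carbon bound to a sulfur), is now made at the same place on the core of compound 3 to reach compound 4. For compound 4 the expected step is a 1.1-fold lower number from compound 3 to compound 4 (0.04 log units; within the scatter), resting on the earlier step of a 1.1-fold lower number from compound 1 to compound 2 (0.05 log units; within the scatter). Compound 4 is therefore estimated at 35000 nM, with a range from 18000 nM to 70000 nM.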

Compound 4, half-maximal inhibitory concentration: 35100 nM
The estimate for compound 4 lay 1.0-fold (0.00 log units) below the measured number; the measured number falls inside the stated range.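

With (2-fluorophenoxy)methyl in place of 2,6-difluorophenyl on the second core, this assay gave a 1.1-fold lower number from compound 3 to compound 4 (0.04 log units; within the scatter). Set beside the earlier step, the change reads the same on both cores: the same change on two cores in this assay, a 1.1-fold lower number (0.05 log units; within the scatter) from compound 1 to compound 2 and a 1.1-fold lower number (0.04 log units; within the scatter) from compound 3 to compound 4, 1.0-fold (0.01 log units) apart, within the scatter of two such steps

Both steps lie within the scatter, so the agreement is between two results that show no readable effect; it does not show that a change with a real effect would carry across these cores, or that this one would behave alike on a third core.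

The compounds shown leave open whether an amine, a carboxylic acid or a longer chain at this place would move the number in this assay. They also leave open what a nitrile in place of the trifluoromethyl would do.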